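A few compounds are considered here, and "the series" means these few. Any claim that something is new, unique, unknown or untested is made for them only; others in the source may bear on it.

Compound 1 `CCC1(Cc2ccccc2)OS(=O)(=O)C=C1OCc1ccc([N+](=O)[O-])cc1` is one of three compounds with a result in an ADME assay on HEL cells (Homo sapiens) for cytotoxicity, with a stated time of 3 days; a higher number here means that more compound is tolerated, a lower number that less compound is tolerated. In this assay compound 1 gives >= 80000 nM, which is a limit of the assay and not a number. Compound 2 `CCC1(Cc2ccccc2)OS(=O)(=O)C=C1OCC#N` gives in this assay > 400000 nM, again a limit. Compound 3 `CCC1(Cc2ccccc2)OS(=O)(=O)C=C1OCCCCc1ccccc1` gives in this assay >= 20000 nM, also a limit. With every value a limit, compound 1 cannot be ranked against the other two, and the steps a step that the two limits leave unreadable from compound 1 to compound 2, a step that the two limits leave unreadable from compound 1 to compound 3 and a step that the two limits leave unreadable from compound 2 to compound 3 have no readable size.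

Compound 4 `CCC1(Cc2ccccc2)OS(=O)(=O)C=C1OCc1ccc(C(F)(F)F)cc1` differs from compound 1 in one place: trifluoromethyl in place of nitro on an aromatic carbon. The group sits on an aromatic carbon of a six-membered aromatic ring of carbon only, para to a large group. Among the measured compounds shown here, none of the measured steps changes this ring; each swaps the whole group on the saturated chain carbon, and none has a readable size, so they give no measure of what to expect. In the absence of a readable step, compound 4 is expected to show no step beyond the scatter, an expected step of a number no higher from compound 1 to compound 4 (the limit leaves the size open). Compound 4 is therefore estimated at 80000 nM, between 20000 nM and 400000 nM, with a good chance that only a limit is reported.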

Compound 4, minimum cytotoxic concentration: >= 16000 nM
Compound 4 gave a limit, no number; the forecaster's own chance of this, stated with the estimate: 70%; the middle value lies beyond the limit too.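

Among the compounds shown here, compound 4, like compound 1, gives only a limit in this assay, so no step between compound 1 and compound 4 can be read. The compounds shown leave open whether trifluoromethyl in place of nitro alters how much compound is tolerated.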